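A Ring Swap Judged Against Three Assay Limits

A few compounds are considered here, and "the series" means these few. Any claim that something is new, unique, unknown or untested is made for them only; others in the source may bear on it.

In a functional assay on MCF cells (Homo sapiens) for antiproliferative activity, with a stated time of 72 h (a higher number here means a weaker inhibitor, a lower number a stronger inhibitor), compound 2 (`Cc1cccc(CNc2ncnc3c2ncn3[C@@H]2O[C@H](CO)[C@@H](O)[C@H]2O)c1`) gives > 166000 nM as its reading, which is a limit and not a number. Compound 1 (`OC[C@H]1O[C@@H](n2cnc3c(NCc4cccc(Br)c4)ncnc32)[C@H](O)[C@@H]1O`) gives > 166000 nM in this assay as a limit too. Compound 3 (`COc1cccc(CNc2ncnc3c2ncn3[C@@H]2O[C@H](CO)[C@@H](O)[C@H]2O)c1`) gives > 166000 nM in this assay as a limit as well. Compound 2 therefore stands with its two neighbours, and none of the three has a measured number.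

Compound 4 (`COc1ccc(CNc2ncnc3c2ncn3[C@@H]2O[C@H](CO)[C@@H](O)[C@H]2O)c(OC)c1`) has not yet been measured. It carries 2,4-dimethoxyphenyl in place of 3-methylphenyl on a saturated chain carbon bound to a nitrogen on an aromatic ring.

Among the compounds with values here, three measured steps bear on this change. The nearest is a step that the two limits leave unreadable from compound 2 to compound 3 with methoxy in place of methyl. The others are a step that the two limits leave unreadable from compound 1 to compound 2 with methyl in place of bromo and a step that the two limits leave unreadable from compound 1 to compound 3 with methoxy in place of bromo. None of them has a readable size, so they give no direction. Because the limit of > 166000 nM in this assay, at which 3 of the 3 values shown sit, is the whole of the evidence, no step beyond the scatter is expected for compound 4 in this assay on these data.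

The expected change is a number no higher from compound 2 to compound 4 (the limit leaves the size open) as an estimate only. The estimate for compound 4 is 166000 nM with an expected range from 60000 nM to 300000 nM in this assay when it is measured.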

Compound 4, half-maximal inhibitory concentration: > 166000 nM
Compound 4: only a limit was reported; the forecaster's own chance of this, stated with the estimate: 80%; the middle value sits exactly at the limit.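

Compound 4 also gives only a limit, so the steps linking it to compound 1, compound 2 and compound 3 cannot be read, and none of them has a size or a direction: the limit of > 166000 nM in this assay, at which 4 of the 4 values shown sit.

The compounds shown leave open how the 3-bromophenyl, 3-methylphenyl, 3-methoxyphenyl and 2,4-dimethoxyphenyl compounds truly compare in this assay, since none has a measured number there.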